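Pyrazin-2-yl for pyridin-3-yl at a shared limit

The source may report more compounds than this note shows. Statements on the series, on what has been measured and on what is new or still open speak of the compounds shown alone.

In a physicochemical assay for solubility, read by HPLC, in phosphate buffer, measured as kinetic solubility, with a stated time of 1 h, at pH 7.4, tested at 250 uM (on this read-out higher numbers stand for higher solubility and lower numbers for lower solubility), compound 1 `COc1cccc(-c2cn(C(=O)NCCCCc3ccccc3)c(=O)o2)c1` gives < 1000 nM as a limit and not a number. Compound 2 `O=C(NCCCCc1ccccc1)n1cc(-c2ccccn2)oc1=O` gives < 1000 nM as a limit too. Compound 3 `O=C(NCCCCc1ccccc1)n1cc(-c2cccnc2)oc1=O` gives < 1000 nM as a limit as well, so it has no exact position. The whole set shows the limit of < 1000 nM in this assay, at which 3 of the 3 values shown sit, and nothing finer. Compound 4 `O=C(NCCCCc1ccccc1)n1cc(-c2cnccn2)oc1=O` carries pyrazin-2-yl in place of pyridin-3-yl on an aromatic carbon, as counted here: pyrazin-2-yl in place of pyridin-3-yl on an aromatic carbon and the rest is unchanged. The closest evidence is a step that the two limits leave unreadable from compound 2 to compound 3 together with a step that the two limits leave unreadable from compound 1 to compound 3 and neither gives a size. No step beyond the scatter is therefore expected in this assay in either direction. The expected change is a step that the limit leaves unreadable from compound 3 to compound 4 as an estimate only. Compound 4 is estimated at 600 nM with an expected range from 200 nM to 1500 nM and may well return only a limit.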

Compound 4, solubility: < 1000 nM
Compound 4 was reported as a limit (the forecaster's own chance of this, stated with the estimate: 80%); the middle value lies beyond the limit too.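

Among the compounds shown here, compound 4, like compound 1, compound 2 and compound 3, returns only a limit in this assay, so no step between them can be read: the limit of < 1000 nM in this assay, at which 4 of the 4 values shown sit. On these data alone, the actual solubility of each compound, and how pyrazin-2-yl compares with the other groups, stays open.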